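Amide core series: chloro to methyl swap at the fused ring

The compounds below may be only part of what the source reports. "The series", "measured", "known", "first", "only" and "open" are said of these compounds alone.

Measured so far:
- compound 1, `O=C(CCCc1ccccc1)Nc1nc2ccc(Cl)cc2c(=O)s1`: > 10000 nM
- compound 2, `CN(C(=O)CCCc1ccccc1)c1nc2ccccc2c(=O)s1`: 53.1 nM

In an in vitro assay on cells for inhibition of Amine oxidase [flavin-containing] B (Homo sapiens), read by fluorescence and Amplex Red, with stated times of 30 min and 45 min (a higher number here means a weaker inhibitor, a lower number a stronger inhibitor), compound 1 gives only a limit, > 10000 nM, so its true position is not fixed by a number; this is the case described by the limit of > 10000 nM in this assay, at which 1 of the 2 values shown sits. Among the measured compounds shown here, compound 2 gives 53.1 nM in this assay, but it differs from compound 1 in more than one place, so no single step between them can be read.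

Compound 3, `Cc1ccc2nc(NC(=O)CCCc3ccccc3)sc(=O)c2c1`, carries the change (methyl in place of chloro on an aromatic carbon). One heavy atom replaces another at the same aromatic position, with no ring, donor or acceptor altered. For the measured compounds named here, no measured step informs this swap. The expected step that the limit leaves unreadable from compound 1 to compound 3 is none beyond the scatter, and compound 3 is estimated at 15000 nM, within 3000 nM to 60000 nM.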

Compound 3, half-maximal inhibitory concentration: 94 nM
Compound 3: middle estimate off by 160-fold (2.20 log units), on the high side; the measured number lies below the stated range.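

In this assay, methyl in place of chloro on this aromatic carbon is far from a neutral swap, giving an at least 100-fold lower number from compound 1 to compound 3 (2.02 log units; beyond the scatter). The exchange of one heavy atom for another, with no ring, donor or acceptor altered, is enough to produce a step of this size at this position. The value of compound 1, > 10000 nM, is a limit and not a number: the limit of > 10000 nM in this assay, at which 1 of the 3 values shown sits.

The compounds shown hold no fluoro, methoxy or amine on this aromatic carbon. Going by these compounds, whether the step reflects something particular to methyl or to chloro therefore stays open.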